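The source may hold more compounds than are shown below. What is called first, only, known or untested is meant among the compounds shown, and "the series" means these compounds.

Measured compounds:
compound 1, `Oc1ccccc1CNc1ccccc1`, gives "not active" (no number reported) in a functional assay on Jurkat cells (Homo sapiens) for activation, with a stated time of 24 h; on this read-out lower numbers stand for an effect already at smaller amounts and higher numbers for an effect only at larger amounts of compound
compound 2, `Cc1ccc(-c2ccc(NCc3ccccc3O)cc2)cc1`, gives 3790 nM in this assay
compound 3, `Oc1ccccc1CNc1ccc(-c2cccc(Cl)c2)cc1`, gives 6200 nM in this assay

Going by the values given here, compound 3 holds the highest of the two numbers recorded, yet the only other number sits a mere a 1.6-fold higher number from compound 2 to compound 3 (0.21 log units; within the scatter) apart, a gap within the scatter, so the two cannot be ranked. Compound 1 has no number at all. Compound 4, `Oc1cccc(-c2ccc(NCc3ccccc3O)cc2)c1`, has not been measured; it differs from compound 3 by hydroxy in place of chloro on an aromatic carbon. Among the compounds with values here, the single measured step, a 1.6-fold higher number from compound 2 to compound 3 (0.21 log units; within the scatter), exchanged one substituted ring for another without leaving the scatter, but no measured pair swaps chloro for hydroxy, so nothing here speaks directly to the new change. Within the data shown here, with only that one step to lean on, the expected movement in this assay is a 1.0-fold lower number from compound 3 to compound 4 (0.01 log units; within the scatter), none beyond the scatter. Compound 4 is therefore estimated at 6000 nM, with a range from 2000 nM to 20000 nM.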

Compound 4, half-maximal effective concentration: "not active" (no number reported)
Compound 4: no number reported; there is nothing to compare the estimate with.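

In this assay compound 4 gives "not active" (no number reported), so no step can be read from compound 3, which gives 6200 nM. No measurement shown offers an explanation for this result. The compounds shown leave open whether hydroxy in place of chloro changes the number at all, and by how much.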